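The source may hold more compounds than are shown below. What is called first, only, known or untested is meant among the compounds shown, and "the series" means these compounds.

Three compounds share one core and differ only in a substituted phenyl group on an amide-type nitrogen. In a functional assay on A549 cells (Homo sapiens) for inhibition, read by MTT assay, with a stated time of 48 h (on this read-out lower numbers stand for stronger inhibition and higher numbers for weaker inhibition), compound 1 `Cc1ccc(NC(=O)Nc2cccc(-c3cccc4[nH]nc(N)c34)c2)cc1` gives 1660 nM, compound 2 `Nc1n[nH]c2cccc(-c3cccc(NC(=O)Nc4ccc(F)c(F)c4)c3)c12` gives 3040 nM, and compound 3 `COc1cccc(NC(=O)Nc2cccc(-c3cccc4[nH]nc(N)c34)c2)c1` gives 2490 nM. Compound 3 cannot be separated from the other two, as the data show a 1.5-fold higher number from compound 1 to compound 3 (0.18 log units; within the scatter) and a 1.2-fold lower number from compound 2 to compound 3 (0.09 log units; within the scatter).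

Compound 4 `Nc1n[nH]c2cccc(-c3cccc(NC(=O)Nc4cccc(C(F)(F)F)c4)c3)c12` carries trifluoromethyl in place of methoxy on an aromatic carbon, meta to a large group (trifluoromethyl in place of methoxy on an aromatic carbon). Going by the values given here, no measured step makes exactly this swap. The nearest guides are the other exchanges on this phenyl group, such as a 1.8-fold higher number from compound 1 to compound 2 (0.26 log units; within the scatter), alongside the two steps already given. None of these exchanges moved the number beyond the scatter, so no step beyond the scatter is expected in this assay, and no direction can be argued. The estimated step is a 1.2-fold lower number from compound 3 to compound 4 (0.07 log units; within the scatter), which is a small one. For compound 4 the expected value is 2100 nM, with an estimated range from 1000 nM to 4500 nM.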

Compound 4, half-maximal inhibitory concentration: 1950 nM
Estimate against measurement, compound 4: 1.1-fold (0.03 log units) above; the range from low to high includes it.
By their numbers in this assay, from the lowest: compounds 1, 4, 3 and 2 (each within the scatter of the next).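

In this assay, replacing methoxy, which counts as a hydrogen-bond acceptor, with trifluoromethyl, which does not, gives a 1.3-fold lower number from compound 3 to compound 4 (0.11 log units; within the scatter) and so does not separate the two compounds. The new group also stays level with the other two phenyl groups, with a 1.6-fold lower number from compound 2 to compound 4 (0.19 log units; within the scatter) and a 1.2-fold higher number from compound 1 to compound 4 (0.07 log units; within the scatter), which means that all four compounds now lie within the scatter of one another, and this read-out does not tell their phenyl groups apart. No measurement here offers an explanation for this flat result.

On these data alone, what remains open is whether a quite different group on this phenyl ring, such as an amine or a carboxylic acid, would move the number beyond the scatter. The compounds shown also leave open whether a change to the shared core, rather than to this phenyl group, would do so.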